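Swapping one ester group on a shared core

A few compounds are considered here, and "the series" means these few. Any claim that something is new, unique, unknown or untested is made for them only; others in the source may bear on it.

- compound 1 `CC(=O)OC/C1=C/C[C@](C)(CCC=C(C)C)/C=C/[C@@H](OC(=O)C=C(C)C)[C@](C)(O)/C=C/C1=O` gives 2950 nM
- compound 2 `CCN(CC)C/C1=C/C[C@](C)(CCC=C(C)C)/C=C/[C@@H](OC(=O)C=C(C)C)[C@](C)(O)/C=C/C1=O` gives 270 nM
- compound 3 `CC(C)=CCC[C@]1(C)/C=C/[C@@H](OC(=O)C=C(C)C)[C@](C)(O)/C=C/C(=O)/C(COC(=O)c2ccc([N+](=O)[O-])cc2)=C\C1` gives 570 nM

All three numbers come from a functional assay on SW480 cells (Homo sapiens) for antiproliferative activity, read by MTT assay, with a stated time of 48 h (a lower number here means a stronger inhibitor, a higher number a weaker inhibitor), and compound 3 has the second highest of them. Compound 4 `CSC(=S)OC/C1=C/C[C@](C)(CCC=C(C)C)/C=C/[C@@H](OC(=O)C=C(C)C)[C@](C)(O)/C=C/C1=O` keeps the core of compound 3 and changes only the group on an oxygen on a saturated carbon (a group of 4 heavy atoms (2 carbon, 2 sulfur; no ring) in place of a group of 11 heavy atoms (7 carbon, 1 nitrogen, 3 oxygen; one six-membered aromatic ring of carbon only), on an oxygen on a saturated carbon). The group that leaves contains the 4-nitrophenyl that gave a modest gain (a 5.2-fold lower number from compound 1 to compound 3 (0.71 log units; beyond the scatter)). This part of the molecule also gave a large step with diethylamino (an 11-fold lower number from compound 1 to compound 2 (1.04 log units; beyond the scatter)). Losing that 4-nitrophenyl could give back part of the gain, so the expected step in this assay is modest and toward a higher number (a 2.3-fold higher number from compound 3 to compound 4 (0.36 log units; beyond the scatter)). For compound 4 the estimate is 1300 nM (expected range 450 nM to 3800 nM).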

Compound 4, half-maximal inhibitory concentration: 390 nM
Estimate against measurement, compound 4: 3.3-fold (0.52 log units) above; measured number outside the range, below it.
By their numbers in this assay, from the lowest: compounds 2, 4 and 3 (each within the scatter of the next, the first and the last beyond it); then compound 1.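

On this oxygen on a saturated carbon, a group with no ring, of 2 carbon and 2 sulfur atoms, still gives a 7.6-fold lower number from compound 1 to compound 4 (0.88 log units; beyond the scatter) in this assay. The aromatic ring of (4-nitrophenyl)carbonyl is therefore not required for this gain, as a 1.5-fold lower number from compound 3 to compound 4 (0.16 log units; within the scatter) and a 1.4-fold higher number from compound 2 to compound 4 (0.16 log units; within the scatter) both stay within the scatter. No measured evidence here explains why these different groups land so close together.

Still open, going by these compounds, is whether a carboxylic acid or a longer chain at this place would hold the same level, and whether morpholine would match diethylamino.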